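Swapping one ring stereocentre in a benzyl glycoside

A few compounds are considered here, and "the series" means these few. Any claim that something is new, unique, unknown or untested is made for them only; others in the source may bear on it.

Compound 1 `O=C1C[C@@H](O[C@H]2O[C@H](CO)[C@@H](O)[C@H](O)[C@H]2O)CN1` is a sugar joined to a small ring that carries an amide-type nitrogen. In a functional assay on RAW264.7 cells (Mus musculus) for inhibition, read by Griess assay, with a stated time of 24 h (on this read-out lower numbers stand for stronger inhibition and higher numbers for weaker inhibition), compound 1 gives 89000 nM. Compound 2 `O=C1C[C@@H](O[C@H]2O[C@H](CO)[C@@H](O)[C@H](O)[C@@H]2O)CN1` shares every atom and bond with compound 1 and differs only in how one saturated ring carbon is drawn; in this assay compound 2 gives 108000 nM. Compound 3 `O=C1C[C@@H](O[C@H]2O[C@H](CO)[C@@H](O)[C@H](O)[C@H]2O)CN1Cc1ccccc1` carries a benzyl group on the ring nitrogen of compound 1; in this assay compound 3 gives 72500 nM, the lowest of the three numbers, though the steps to both others sit within the scatter, so the three cannot be told apart.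

Compound 4 `O=C1C[C@@H](O[C@H]2O[C@H](CO)[C@@H](O)[C@H](O)[C@@H]2O)CN1Cc1ccccc1` stands to compound 3 as compound 2 stands to compound 1. the two compounds have the same atoms and bonds and differ only in configuration as drawn: 1 of 6 stereo elements differ; a stereocentre at a saturated ring carbon is drawn R in compound 3 and S in compound 4

The step of a 1.2-fold higher number from compound 1 to compound 2 (0.08 log units; within the scatter) is the closest guide, and the fact that compounds 1 and 2 differ only in the configuration as drawn makes it the same kind of change; the step of a 1.2-fold lower number from compound 1 to compound 3 (0.09 log units; within the scatter) shows the benzyl group itself changing little. No step beyond the scatter is therefore expected in this assay, only a 1.2-fold higher number from compound 3 to compound 4 (0.07 log units; within the scatter). Compound 4 is estimated at 85000 nM, within 40000 nM to 180000 nM.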

Compound 4, half-maximal inhibitory concentration: 97200 nM
Compound 4: the middle estimate sits 1.1-fold (0.06 log units) below what was measured; the measured number falls inside the stated range.
By their numbers in this assay, from the lowest: compounds 3, 1, 4 and 2 (each within the scatter of the next).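

With the benzyl group on the nitrogen, redrawing this one ring stereocentre from R to S gives a 1.3-fold higher number from compound 3 to compound 4 (0.13 log units; within the scatter), so the swap stays within the scatter here, as it did without the benzyl group. Adding benzyl to the S form gives a 1.1-fold lower number from compound 2 to compound 4 (0.05 log units; within the scatter), so neither change can be told from the scatter in this assay, whichever form of the other place is present. The two changes also appear independent of each other within this set, as the benzyl step reads alike in both stereo forms: the same change on two cores in this assay, a 1.2-fold lower number (0.09 log units; within the scatter) from compound 1 to compound 3 and a 1.1-fold lower number (0.05 log units; within the scatter) from compound 2 to compound 4, 1.1-fold (0.04 log units) apart, within the scatter of two such steps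

From the compounds shown here alone, whether another group on that nitrogen, such as a longer alkyl chain or a benzyl carrying a carboxylic acid, would move the number beyond the scatter stays open. So does the effect of redrawing any of the other stereocentres, which are the same in all four compounds.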